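Replacing One Group on the Top Compound So Far

This account rests on a few compounds, and the source may have more. Where it says the series, first, only, none or still open, it means among the compounds named here.

Two compounds have been measured so far in an ADME assay on microsomes from liver (Homo sapiens) for metabolic stability, read by LC-MS, with a stated time of 10 min (on this read-out higher numbers stand for a more stable compound and lower numbers for a less stable compound), and give these values:

Compound 1 (`CN(C[C@H]1Cc2c(cccc2N2CCN(c3ncccn3)CC2)CN1)[C@H]1CCCc2cccnc21`): 35.5%
Compound 2 (`CN(C[C@H]1Cc2c(cccc2N2C[C@@H]3C[C@H]2CN3)CN1)[C@H]1CCCc2cccnc21`): 100%

Compound 2 stands highest of the two numbers, and the gap down to compound 1 lies beyond the usual scatter. The next compound to be tested is compound 3 (`CN(C[C@H]1Cc2c(cccc2N2CCNCC2)CN1)[C@H]1CCCc2cccnc21`), which differs from compound 2 in one place. The change is a group of 6 heavy atoms (4 carbon, 2 nitrogen; one six-membered non-aromatic ring with 2 hetero atoms) in place of a group of 7 heavy atoms (5 carbon, 2 nitrogen; 2 five-membered non-aromatic rings with 1 hetero atom each), on an aromatic carbon and it falls on an aromatic carbon of a six-membered aromatic ring of carbon only. The entering group is piperazin-1-yl, while the group that leaves has no common name.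

For the measured compounds named here, no measured pair shows this change on its own, so the expectation is a cautious one. Compound 2 at 100% leaves little room for any upward movement, so a modest fall is the likely direction, and a result within the scatter would not be surprising. The expected change is a number 15 percentage points lower from compound 2 to compound 3 (beyond the scatter) in this assay on this reading. For compound 3 the estimate is 85% with an expected range from 62% to 100% as its span.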

Compound 3, percent of the compound remaining: 99.7%
For compound 3 the middle estimate is 14.7 percentage points below the measured one; low and high end bracket the measured number.
By their numbers in this assay, from the lowest: compound 1; then compounds 3 and 2 (each within the scatter of the next).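

In this assay, piperazin-1-yl in place of the group with no common name, on the aromatic carbon ortho to a fused ring, gives a number 0.3 percentage points lower from compound 2 to compound 3 (within the scatter) and so leaves the read-out unmoved at this position. The two defined stereocentres and the second five-membered ring of the leaving group therefore make no difference beyond the scatter on this core. For the compounds shown here, the new compound also provides the first comparison in one place at the amine nitrogen in the ring, where hydrogen in place of pyrimidin-2-yl gives a number 64.2 percentage points higher from compound 1 to compound 3 (beyond the scatter) as a large step, although nothing on hand explains either result.

The compounds shown leave open whether a smaller group on that ring nitrogen, such as methyl or acetyl, would keep the number of the unsubstituted piperazin-1-yl or fall toward that of the pyrimidin-2-yl compound. They also leave open whether pyrimidin-2-yl would have the same large effect on the nitrogen of the two-ring group that compound 3 replaces.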